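This account rests on a few compounds, and the source may have more. Where it says the series, first, only, none or still open, it means among the compounds named here.

Measured so far:
compound 1, `OCCCCC#Cc1ccccc1C#Cc1ccccn1` — 29800 nM
compound 2, `OCCCCC#Cc1ccccc1C#Cc1cccc(C(F)(F)F)c1` — 16300 nM

In a functional assay on HCT-15 cells (Homo sapiens) for cytotoxicity (a lower number here means a stronger inhibitor of growth, a higher number a weaker inhibitor of growth), compound 1 gives 29800 nM, the highest of the two numbers recorded. Compound 2 gives 16300 nM in this assay, and the gap to compound 1 lies within the scatter, so no order between the two can be stated. Both sit in a weak range of growth inhibition.

Compound 3, `OCCCCC#Cc1ccccc1C#Cc1ccc(O)cc1`, is not yet measured. Against compound 1 the change is 4-hydroxyphenyl in place of pyridin-2-yl on a triple-bonded carbon. Going by the values given here, no step between measured compounds is available to guide the estimate, so nothing about the weight of a 4-hydroxyphenyl in place of pyridin-2-yl can be read from the data. The expectation is therefore a step from compound 1 of a 1.4-fold lower number from compound 1 to compound 3 (0.13 log units; within the scatter) that stays within the scatter, in either direction. Compound 3 is estimated to give 22000 nM in this assay, with a range from 7000 nM to 70000 nM.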

Compound 3, concentration for 50% growth inhibition: 14100 nM
The estimate for compound 3 lay 1.6-fold (0.19 log units) above the measured number; measured number inside the range.
By their numbers in this assay, from the lowest: compounds 3, 2 and 1 (each within the scatter of the next, the first and the last beyond it).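

In this assay, the group on a triple-bonded carbon now gives a first readable step: 4-hydroxyphenyl in place of pyridin-2-yl brings a 2.1-fold lower number from compound 1 to compound 3 (0.32 log units; beyond the scatter), a modest change only just beyond the scatter. This position therefore responds to the choice of aromatic group, although compound 3 still sits in a weak range of growth inhibition and lies within the scatter of compound 2, so no order between those two can be stated. No measurement at hand bears on the origin of the step.

As far as these compounds go, the change replaces the pyridin-2-yl ring with an all-carbon ring and adds a hydroxy group in one move, so the share of each remains open; an unsubstituted phenyl would separate the two. Also open, from the compounds shown here alone, is how a 4-aminophenyl or a 4-methoxyphenyl would read at this position.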